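The source may hold more compounds than are shown below. What is called first, only, known or untested is meant among the compounds shown, and "the series" means these compounds.

In an ADME assay on NIH3T3 cells (Mus musculus) for cytotoxicity, read by MTT assay, with a stated time of 48 h (on this read-out higher numbers stand for lower toxicity in this test and lower numbers for higher toxicity in this test), compound 1 `COc1ccc(C(C)=O)cc1S(N)(=O)=O` gives > 2700000 nM, which is a limit of the test and not a number. From the compounds shown here alone, compound 2 `COc1ccc(C(C)=O)cc1S(=O)(=O)Nc1c(N)nc(SC)[nH]c1=O` gives > 1600000 nM, also a limit, so its true position remains open. Compound 3 `COc1ccc(/C=C/C(=O)c2ccc(OC)c(S(=O)(=O)Nc3c(N)nc(SC)[nH]c3=O)c2)cc1` differs from compound 2 in one place: 2-(4-methoxyphenyl)ethenyl in place of methyl on a carbonyl carbon, with 2-(4-methoxyphenyl)ethenyl in place of methyl on a carbonyl carbon. Among the measured compounds shown here, no measured pair shows what this change does, so the expectation is only a rough one. A fall in this assay, meaning higher toxicity, is expected, with an estimated step of an at least 8.0-fold lower number from compound 2 to compound 3 (0.90 log units; beyond the scatter). Compound 3 is expected at an estimated 200000 nM, within a range of 30000 nM to 1200000 nM.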

Compound 3, concentration lethal to 50% of the cells: 6500 nM
Estimate against measurement, compound 3: 31-fold (1.49 log units) above; measured number below the stated range.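

Putting 2-(4-methoxyphenyl)ethenyl in place of methyl on this carbonyl carbon gives this assay its first reading that is a number and not a limit, with an at least 240-fold lower number from compound 2 to compound 3 (2.39 log units; beyond the scatter). Compound 1 and compound 2 could not show that toxicity in this test responds to a change at this place. From the compounds shown here alone, the true size of the step remains open because compound 2 sits at a limit of the test: the limit of > 1600000 nM in this assay, at which 1 of the 3 values shown sits.

Going by these compounds, it also remains open whether the aromatic ring or the double bond matters more. An amine or a longer chain at this carbonyl carbon is likewise untested among the compounds shown.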